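Notes on amine replacements at the piperidine of a tryptamine series

The source may report more compounds than this note shows. Statements on the series, on what has been measured and on what is new or still open speak of the compounds shown alone.

Measured so far:
compound 1 `O=S(=O)(NCC1CCN(CCCc2c[nH]c3ccc(-n4cnnc4)cc23)CC1)c1ccccc1` — 73%
compound 2 `COC[C@H](NC1CCN(CCCc2c[nH]c3ccc(-n4cnnc4)cc23)CC1)c1ccccc1` — 93%
compound 3 `CN(Cc1ccccc1)CC1CCN(CCCc2c[nH]c3ccc(-n4cnnc4)cc23)CC1` — 93%

In a functional assay on CHO cells for activation of 5-hydroxytryptamine receptor 1D (Homo sapiens), read by GTPgammaS binding (on this read-out higher numbers stand for larger maximal responses and lower numbers for smaller maximal responses), compound 2 gives 93%, level with compound 3 and together with it the highest of the three numbers; compound 1 lies furthest away, with a number 20 percentage points higher from compound 1 to compound 2 (beyond the scatter) separating them. Compound 2 and compound 3 are not distinguished from each other, no change at the digits printed from compound 2 to compound 3 (within the scatter).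

Compound 4 `CC(=O)Nc1ccc(CNC2CCN(CCCc3c[nH]c4ccc(-n5cnnc5)cc34)CC2)cc1` is not yet measured. Its difference from compound 2: 4-acetamidobenzyl in place of 2-methoxy-1-phenylethyl on an amine nitrogen. The amine nitrogen on the saturated ring carbon is kept, and a benzyl-type group is attached to it, as in compound 3.

Going by the values given here, the steps that bear on this change are a number 20 percentage points higher from compound 1 to compound 2 (beyond the scatter) and no change at the digits printed from compound 2 to compound 3 (within the scatter). The first shows that the move from a sulfonamide to an amine at this position raised the maximal response beyond the scatter; the second shows that exchanging one amine substituent for another left the number unchanged. Among the compounds with values here, no step covers an acetamido group. On this basis the step of a number 3 percentage points lower from compound 2 to compound 4 (within the scatter) is expected to stay within the scatter, with no clear direction. Compound 4 is therefore estimated to reach 90%, in the range 78% to 100%.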

Compound 4, largest response reached (reported as efficacy), in percent of the reference or control that the assay uses: 75%
Beside the measured number, compound 4's estimate is 15 percentage points above it, and the stated range ends above it.
By their numbers in this assay, from the lowest: compounds 1 and 4 (each within the scatter of the next); then compounds 2 and 3 (each within the scatter of the next).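

In this assay, keeping the amine nitrogen on the saturated ring carbon does not by itself hold the response, as the group on that nitrogen gives a number 18 percentage points lower from compound 2 to compound 4 (beyond the scatter). The earlier amine pair showed only no change at the digits printed from compound 2 to compound 3 (within the scatter), so compound 4 adds the first sign that the maximal response depends on the substituent attached to this nitrogen. The change adds a hydrogen-bond donor and removes the defined stereocentre in a single step, and no measured evidence explains the loss of response.

The shown compounds cannot separate the effect of the acetamido group from the loss of 2-methoxy-1-phenylethyl. An unsubstituted benzyl or a 4-methoxybenzyl on the same amine nitrogen would be needed to tell whether the group at the 4-position of the benzyl accounts for the step.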